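A few compounds are considered here, and "the series" means these few. Any claim that something is new, unique, unknown or untested is made for them only; others in the source may bear on it.

Compound 1 `COc1cccc(N2CCNC(=O)N2)c1` gives 47000 nM in an assay on RBL-1 cells for inhibition of Polyunsaturated fatty acid 5-lipoxygenase (Rattus norvegicus); a higher number here means a weaker inhibitor, a lower number a stronger inhibitor.
Compound 2 `CSc1cccc(N2CCNC(=O)N2)c1` gives 14000 nM in this assay.
Compound 3 `CC(C)C1CN(c2ccccc2)NC(=O)N1` gives 6800 nM in this assay.

Among these three, compound 3 stands at the lowest number, which in this assay means the strongest inhibition seen so far. Its nearest neighbour is compound 2, whose number is higher by a margin beyond the scatter, and compound 1 lies furthest away with a higher number still. Among the measured compounds shown here, the only step between measured compounds that changes a single place is a 3.4-fold lower number from compound 1 to compound 2 (0.53 log units; beyond the scatter); it concerns a group on the aromatic ring, not the saturated ring of the shared core.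

Compound 4 `O=C1NC(CO)CN(c2ccccc2)N1` differs from compound 3 in one place: hydroxymethyl in place of isopropyl on a saturated ring carbon. For the measured compounds named here, no measured step touches this part of the core or either of these groups, so the one step on record offers only a sense of how far a small exchange can move the number, and gives no direction for this case. Going by the values given here, with no direct precedent, the expectation for compound 4 is a modest shift to a higher number, a 2.2-fold higher number from compound 3 to compound 4 (0.34 log units; beyond the scatter), held with wide uncertainty. The estimate for compound 4 in this assay is 15000 nM, within a range from 5000 nM to 50000 nM.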

Compound 4, half-maximal inhibitory concentration: 40000 nM
Compound 4: the middle estimate sits 2.7-fold (0.43 log units) below what was measured; measured number inside the range.
By their numbers in this assay, from the lowest: compound 3; then compound 2; then compounds 4 and 1 (each within the scatter of the next).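

In this assay the exchange at this saturated ring carbon gives a 5.9-fold higher number from compound 3 to compound 4 (0.77 log units; beyond the scatter), so the number responds to what this position carries, something the earlier step on the aromatic ring could not show. The exchange removes isopropyl, with 3 heavy atoms, all carbon, and no hydrogen-bond donor or acceptor, and brings in hydroxymethyl, with 2 heavy atoms, one of them oxygen, plus 1 hydrogen-bond donor and 1 hydrogen-bond acceptor; in this single pair, the all-carbon group goes with the stronger inhibition. Group size and the arrival of oxygen change together in this step, and no separate measurement is available to explain the difference or to tell these two changes apart.

An ethyl group at the same carbon would hold the group free of oxygen while shortening it, and a methoxymethyl group would keep the oxygen but remove the hydroxyl hydrogen, so either could help separate the two changes. As far as these compounds go, how a longer carbon chain such as butyl, an amine or a carboxylic acid would fare at this position also remains open, as does whether the step would be similar on a core carrying methylsulfanyl on the aromatic ring.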